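Methoxy in place of amino on a weakly active core

This account rests on a few compounds, and the source may have more. Where it says the series, first, only, none or still open, it means among the compounds named here.

Compound 2 (`Nc1ncnc2[nH]cc(Sc3cccs3)c12`) gives > 50000 nM in a functional assay on HCT-116 cells (Homo sapiens), read by MTT assay, with a stated time of 3 days (on this read-out lower numbers stand for stronger inhibition and higher numbers for weaker inhibition), and that value is a limit, not a number (the limit of > 50000 nM in this assay, at which 1 of the 3 values shown sits). Compound 1 (`CN(C)c1ncnc2[nH]cc(Sc3cccs3)c12`) gives 27500 nM on this read-out. Compound 3 (`Cc1ncnc2[nH]cc(Sc3cccs3)c12`) gives 29100 nM on the same read-out. Compound 4 (`COc1ncnc2[nH]cc(Sc3cccs3)c12`) carries methoxy in place of amino on an aromatic carbon. For the measured compounds named here, the closest precedent is methyl in place of the same amino (an at least 1.7-fold lower number from compound 2 to compound 3 (0.23 log units; that floor lies within the scatter)). Two further steps bear on it (an at least 1.8-fold higher number from compound 1 to compound 2 (0.25 log units; that floor lies within the scatter); a 1.1-fold higher number from compound 1 to compound 3 (0.02 log units; within the scatter)). All three stay small, so only a modest move towards a lower number is expected, possibly none beyond the scatter. The estimated change is an at least 1.5-fold lower number from compound 2 to compound 4 (0.18 log units; that floor lies within the scatter) in this assay and a limit reading remains possible. For compound 4 the expected value is 33000 nM within an estimated range from 15000 nM to 60000 nM on this read-out.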

Compound 4, half-maximal inhibitory concentration: > 50000 nM
Compound 4 was reported as a limit (the forecaster's own chance of this, stated with the estimate: 30%); middle value at least 1.5-fold (0.18 log units) away from the limit.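

In this assay compound 4 gives a limit, not a number, as compound 2 does, so the step between these two cannot be read: the limit of > 50000 nM in this assay, at which 2 of the 4 values shown sit. The steps of an at least 1.7-fold higher number from compound 3 to compound 4 (0.23 log units; that floor lies within the scatter) and an at least 1.8-fold higher number from compound 1 to compound 4 (0.25 log units; that floor lies within the scatter) can be read, but both are floors within the scatter. Methoxy on this aromatic carbon therefore gives no lower number, yet it is not separated from methyl or dimethylamino either.

As far as these compounds go, it stays open whether ethoxy, a longer chain, or morpholine, a cyclic amine, at this place would give a reading clearly beyond the scatter.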